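Side-chain notes: compound 3 to compound 4

This account rests on a few compounds, and the source may have more. Where it says the series, first, only, none or still open, it means among the compounds named here.

compound 1 `COc1cc2ncnc(-n3nc(-c4ccccn4)nc3N)c2cc1OCCCN(C)C`: 53000 nM
compound 2 `COc1cc2ncnc(-n3nc(-c4ccccn4)nc3N)c2cc1OCCCN1CC(C)OC(C)C1`: 8000 nM
compound 3 `COc1cc2ncnc(-n3nc(-c4ccccn4)nc3N)c2cc1OCCCNC(=O)OC(C)(C)C`: 2000 nM

All three values come from a physicochemical assay for solubility, in phosphate buffer, with a stated time of 18 h, at pH 7.4; a higher number here means a more soluble compound, a lower number a less soluble compound. Compound 3 has the lowest number of the three, and both gaps are beyond the scatter: a 4.0-fold lower number from compound 2 to compound 3 (0.60 log units; beyond the scatter) and a 27-fold lower number from compound 1 to compound 3 (1.42 log units; beyond the scatter).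

Compound 4 `COc1cc2ncnc(-n3nc(-c4ccccn4)nc3N)c2cc1OCCCCNC(=O)OC(C)(C)C` is not yet measured. Its difference from compound 3 is ((tert-butoxycarbonyl)amino)methyl in place of (tert-butoxycarbonyl)amino on a saturated chain carbon, three bonds along the chain from an oxygen on an aromatic ring. In words, ((tert-butoxycarbonyl)amino)methyl stands in place of (tert-butoxycarbonyl)amino on a saturated chain carbon, three bonds along the chain from an oxygen on an aromatic ring. Cut further out, this reads 3-((tert-butoxycarbonyl)amino)propyl to 4-((tert-butoxycarbonyl)amino)butyl.

The measured steps, a 6.6-fold lower number from compound 1 to compound 2 (0.82 log units; beyond the scatter) and the two above, all exchange the group at the chain end. None lengthens the chain with that group kept, so they bear on this change only indirectly. Compound 4 keeps the end group of compound 3, and the nearest reference is therefore compound 3 at 2000 nM. A small step towards a lower number is expected in this assay, possibly none beyond the scatter, though no measurement tests the direction. The expected step is a 1.3-fold lower number from compound 3 to compound 4 (0.12 log units; within the scatter). For compound 4 the estimated value is 1500 nM, with an expected range of 600 nM to 3500 nM.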

Compound 4, solubility: 500 nM
Compound 4: middle estimate off by 3.0-fold (0.48 log units), on the high side; measured number below the stated range.
By their numbers in this assay, from the lowest: compound 4; then compound 3; then compound 2; then compound 1.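

In this assay compound 4 keeps the (tert-butoxycarbonyl)amino end group and changes only the chain, from 3-((tert-butoxycarbonyl)amino)propyl to 4-((tert-butoxycarbonyl)amino)butyl, and this alone moves the read-out beyond the scatter (a 4.0-fold lower number from compound 3 to compound 4 (0.60 log units; beyond the scatter)), a step as large as the exchange of end group printed earlier (a 4.0-fold lower number from compound 2 to compound 3 (0.60 log units; beyond the scatter)). Chain length at this position therefore matters in its own right, and compound 4 now has the lowest number of the four, extending the gaps to the compounds with tertiary amine ends (a 16-fold lower number from compound 2 to compound 4 (1.20 log units; beyond the scatter); a 110-fold lower number from compound 1 to compound 4 (2.03 log units; beyond the scatter)), although those two steps change the chain and the end group together and do not separate the two. No supporting data on the origin of the step from propyl to butyl are available.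

Still open, from the compounds shown here alone, is whether a longer chain, such as 5-((tert-butoxycarbonyl)amino)pentyl, continues in the same direction, and whether the step from propyl to butyl recurs with dimethylamino or 2,6-dimethylmorpholin-4-yl at the chain end. Also open, going by these compounds, is where a primary amine or a carboxylic acid at the end of the butyl chain would stand against these four numbers.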